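Acrylamide replacing chloroacetamide on a carboxylic acid analogue

The compounds below may be only part of what the source reports. "The series", "measured", "known", "first", "only" and "open" are said of these compounds alone.

Among three measured compounds, compound 3 `O=C(CCl)Nc1cccc(Cn2nc(-c3ccc(Oc4ccccc4)cc3)cc2C(=O)O)c1` gives the lowest number in a functional assay on Maver1 cells (Homo sapiens) for inhibition, read by luminescence and CellTiter-Glo, with a stated time of 72 h (on this read-out lower numbers stand for stronger inhibition and higher numbers for weaker inhibition), at 4700 nM; compound 2 `C=CC(=O)Nc1cccc(Cn2nc(-c3ccc(Oc4ccccc4)cc3)cc2CO)c1` gives 6700 nM and compound 1 `C=CC(=O)Nc1cccc(Cn2nc(-c3ccc(Oc4ccccc4)cc3)cc2C(=O)OCC)c1` gives 8600 nM, both within the scatter of compound 3. Among the measured compounds shown here, the only single-point step, a 1.3-fold lower number from compound 1 to compound 2 (0.11 log units; within the scatter), concerns a different position and does not bear on the change at hand. Compound 4 `C=CC(=O)Nc1cccc(Cn2nc(-c3ccc(Oc4ccccc4)cc3)cc2C(=O)O)c1` differs from compound 3 by vinyl in place of chloromethyl on a carbonyl carbon. For the measured compounds named here, no measured pair isolates this change, so the step from compound 3 is expected to stay within the scatter, as a 1.1-fold higher number from compound 3 to compound 4 (0.03 log units; within the scatter). Compound 4 is therefore estimated at 5000 nM in this assay, with a range from 1500 nM to 16000 nM.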

Compound 4, half-maximal inhibitory concentration: 37400 nM
For compound 4 the middle estimate is 7.5-fold (0.87 log units) below the measured one; the measured number lies above the stated range.
By their numbers in this assay, from the lowest: compounds 3, 2 and 1 (each within the scatter of the next); then compound 4.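

In this assay, vinyl in place of chloromethyl on the carbonyl carbon gives an 8.0-fold higher number from compound 3 to compound 4 (0.90 log units; beyond the scatter), so with the carboxy group held fixed, this position does not tolerate the change silently. With the vinylcarbonyl group held fixed, the carboxy group also stands apart: carboxy in place of hydroxymethyl gives a 5.6-fold higher number from compound 2 to compound 4 (0.75 log units; beyond the scatter), and hydrogen in place of ethyl gives a 4.3-fold higher number from compound 1 to compound 4 (0.64 log units; beyond the scatter). No evidence is available that accounts for these steps. On these data alone, whether chloromethyl would give the same step alongside hydroxymethyl or ethoxycarbonyl remains open, as does how a primary amide would read in place of the carboxy group.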